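One Small Change, Tested Twice on Related Compounds

The source may hold more compounds than are shown below. What is called first, only, known or untested is meant among the compounds shown, and "the series" means these compounds.

Compound 1 `COc1ccc2[nH]c(C)c(C3=C(Br)C(=O)C(c4c(-c5ccccc5)[nH]c5ccccc45)=C(Br)C3=O)c2c1` and compound 2 `Cc1[nH]c2ccccc2c1C1=C(Br)C(=O)C(c2c(-c3ccccc3)[nH]c3ccccc23)=C(Br)C1=O` share a core and differ in a single spot. In a functional assay on MDA-MB-231 cells (Homo sapiens) for antiproliferative activity, read by CCK-8 assay, with a stated time of 48 h (on this read-out lower numbers stand for stronger inhibition and higher numbers for weaker inhibition), compound 1 gives 5.02 ug/mL, and compound 2 gives 5.64 ug/mL. The change between them is hydrogen in place of methoxy on an aromatic carbon, and the step it made, a 1.1-fold higher number from compound 1 to compound 2 (0.05 log units; within the scatter), is small. Compound 3 `COc1ccc2[nH]c(C)c(C3=C(Br)C(=O)C(Br)=C(c4c(-c5ccccc5)[nH]c5ccccc45)C3=O)c2c1` is built from the same atoms as compound 1, but they are joined differently; the difference between the two cores is not broken down here. In this assay compound 3 gives 7.67 ug/mL, a number close to the other two. Compound 4 `Cc1[nH]c2ccccc2c1C1=C(Br)C(=O)C(Br)=C(c2c(-c3ccccc3)[nH]c3ccccc23)C1=O` has not been measured; it stands to compound 3 as compound 2 stands to compound 1, the change being (hydrogen in place of methoxy on an aromatic carbon). The surroundings of the altered spot are described in exactly the same words both times, so this is the same change, not merely the same kind. Because a 1.1-fold higher number from compound 1 to compound 2 (0.05 log units; within the scatter) hardly moved the number, a similarly small step is expected here: a 1.1-fold higher number from compound 3 to compound 4 (0.05 log units; within the scatter). Compound 4 is therefore estimated at 8.6 ug/mL, with a likely range from 4.5 ug/mL to 16 ug/mL.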

Compound 4, half-maximal inhibitory concentration: 4.33 ug/mL
The estimate for compound 4 lay 2.0-fold (0.30 log units) above the measured number; measured number outside the range, below it.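

Swapping methoxy for hydrogen on the core of compound 3 gave a 1.8-fold lower number from compound 3 to compound 4 (0.25 log units; within the scatter) in this assay. Set beside the first case, the two steps do not differ by more than the usual scatter, so nothing here suggests that this change behaves differently on the two cores: the same change on two cores in this assay, a 1.1-fold higher number (0.05 log units; within the scatter) from compound 1 to compound 2 and a 1.8-fold lower number (0.25 log units; within the scatter) from compound 3 to compound 4, 2.0-fold (0.30 log units) apart, within the scatter of two such steps. Going by these compounds alone, this does not prove that the change always carries over, since it rests on only two pairs of compounds, and with both steps inside the scatter it cannot tell whether the swap has any real effect in this assay or whether a small difference between the cores lies hidden in the noise.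

The compounds shown carry only methoxy or hydrogen at this spot, so it remains open whether an amine, a carboxylic acid or a longer chain such as butoxy would move the number beyond the scatter. From the compounds shown here alone, it also remains open whether the two steps would stay alike in other cell lines.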